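A few compounds are considered here, and "the series" means these few. Any claim that something is new, unique, unknown or untested is made for them only; others in the source may bear on it.

Compound 1, `O=C(Nc1ccc(Cl)c(-c2nc3ccccc3[nH]2)c1)c1ccc(Br)o1`: in an in vitro functional assay on HEK293-A cells for antagonist activity at metabotropic glutamate receptor 5 (Rattus norvegicus), read by calcium flux (on this read-out lower numbers stand for stronger inhibition and higher numbers for weaker inhibition), compound 1 gives 85 nM.
Compound 2, `COc1ccccc1C(=O)Nc1cccc(NC(=O)c2ccc(Cl)c(Cl)c2)c1`: in this assay compound 2 gives > 30000 nM, which is a limit of the assay and not a number.
Compound 3, `COc1ccccc1C(=O)Nc1cccc(NC(=O)c2cc(Cl)cc(Cl)c2)c1`: in this assay compound 3 gives > 30000 nM, again a limit rather than a number.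

Compound 2 therefore stands at the limit (the limit of > 30000 nM in this assay, at which 2 of the 3 values shown sit), with no numeric potency of its own. Compound 4, `COc1ccccc1C(=O)Nc1cccc(NC(=O)c2ccco2)c1`, differs from compound 2 by furan-2-yl in place of 3,4-dichlorophenyl on a carbonyl carbon. Among the measured compounds shown here, the only measured step within this core, a step that the two limits leave unreadable from compound 2 to compound 3, runs between two limits and says nothing about size or direction. For the measured compounds named here, compound 1 does carry a numeric value, but it sits on a different core and no step connects it to compound 2, so it offers no read on the furan exchange here. With nothing readable to build on, the expectation for compound 4 is that it remains at the same limit, so the step from compound 2 to compound 4 is expected to be a number no higher from compound 2 to compound 4 (the limit leaves the size open), nothing beyond the scatter. Compound 4 is estimated at 30000 nM, within 8000 nM to 100000 nM.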

Compound 4, half-maximal inhibitory concentration: > 30000 nM
Compound 4 ended at the assay's limit; the forecaster's own chance of this, stated with the estimate: 75%; the middle value sits exactly at the limit.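

Compound 4 sits at the same limit as compound 2 and compound 3, so no step among these three can be read: the limit of > 30000 nM in this assay, at which 3 of the 4 values shown sit.

The compounds shown leave open whether any group on that carbonyl carbon would bring the shared core to a numeric value in this assay.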